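Swapping 3,5-dimethylphenyl for phenyl on compound 1

The source may report more compounds than this note shows. Statements on the series, on what has been measured and on what is new or still open speak of the compounds shown alone.

In a functional assay on CHP-134 cells (Homo sapiens) for antiproliferative activity, with a stated time of 72 h (a lower number here means a stronger inhibitor, a higher number a weaker inhibitor), compound 1 (`Cc1ccc(NC(=O)CCN(Cc2ccc(C(=O)NO)cc2)C(=O)c2cc(C)cc(C)c2)cc1`) gives 380 nM. Compound 2 (`Cc1ccc(CNC(=O)CCN(Cc2ccc(C(=O)NO)cc2)C(=O)c2ccc(N(C)C)cc2)cc1`) gives 420 nM, so the two stand level, within the usual scatter of each other. Compound 3 (`Cc1ccc(NC(=O)CCN(Cc2ccc(C(=O)NO)cc2)C(=O)c2ccccc2)cc1`) keeps the core of compound 1 but has phenyl in place of 3,5-dimethylphenyl on a carbonyl carbon. Going by the values given here, no measured pair shows this change alone, so the expectation is only tentative: a modest rise in the number, meaning a slightly weaker inhibitor, with an estimated step of a 1.3-fold higher number from compound 1 to compound 3 (0.12 log units; within the scatter). For compound 3 the estimated value is 500 nM, within a range of 200 nM to 1200 nM.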

Compound 3, half-maximal inhibitory concentration: 1160 nM
Estimate against measurement, compound 3: 2.3-fold (0.37 log units) below, and the stated range covers the measured number.
By their numbers in this assay, from the lowest: compounds 1 and 2 (each within the scatter of the next); then compound 3.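

Replacing 3,5-dimethylphenyl with phenyl on this carbonyl carbon gives a 3.1-fold higher number from compound 1 to compound 3 (0.48 log units; beyond the scatter) in this assay and so weakens the inhibitor. The two methyl groups therefore matter at this position, although the change removes only carbon atoms and leaves the hydrogen-bond donor and acceptor counts at zero. Nothing measured here explains this loss. On these data alone, it remains open whether a single methyl group would recover the activity, and how a methoxy group or a chlorine atom on this ring would compare.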